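A fluoro-to-methyl swap at a limit of the assay

A few compounds are considered here, and "the series" means these few. Any claim that something is new, unique, unknown or untested is made for them only; others in the source may bear on it.

- compound 1 `O=[N+]([O-])c1ccc(Nc2nnc(-c3c[nH]c4ccccc34)o2)cc1` gives 3540 nM
- compound 2 `Clc1cccc(Nc2nnc(-c3c[nH]c4ccccc34)o2)c1` gives 8890 nM
- compound 3 `Fc1ccc(Nc2nnc(-c3c[nH]c4ccccc34)o2)cc1` gives > 100000 nM as a limit

All three values come from a functional assay on MDA-MB-231 cells (Homo sapiens) for inhibition, read by MTT assay, with a stated time of 72 h (a lower number here means a stronger inhibitor, a higher number a weaker inhibitor), and share one core. Compound 3 gives no number there, only the limit > 100000 nM as its reading. Two measured steps end at this compound. One is an at least 28-fold higher number from compound 1 to compound 3 (1.45 log units; beyond the scatter) with fluoro in place of nitro on an aromatic carbon. The other is an at least 11-fold higher number from compound 2 to compound 3 (1.05 log units; beyond the scatter) with 4-fluorophenyl in place of 3-chlorophenyl on a nitrogen on an aromatic ring. Both are large.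

Compound 4 `Cc1ccc(Nc2nnc(-c3c[nH]c4ccccc34)o2)cc1` carries methyl in place of fluoro on an aromatic carbon, para to a large group, a change counted as methyl in place of fluoro on an aromatic carbon here. The two measured steps bear on it only indirectly, since neither of them introduces methyl. They do show that both compounds without fluoro gave a number. Going by compound 2 at 8890 nM as the nearer guide, a large step towards a lower number is expected in this assay. Compound 4 could also stay at the limit. The estimated change is an at least 6.6-fold lower number from compound 3 to compound 4 (0.82 log units; beyond the scatter) for this pair. For compound 4 the expected value is 15000 nM within an estimated range of 3000 nM to 80000 nM in this measurement.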

Compound 4, half-maximal inhibitory concentration: 27300 nM
Estimate against measurement, compound 4: 1.8-fold (0.26 log units) below, and the stated range covers the measured number.
By their numbers in this assay, from the lowest: compound 1; then compound 2; then compound 4. At a limit, above all of these: compound 3.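

In this assay, methyl in place of fluoro on an aromatic carbon, para to a large group, turns a reading with no number into a measured value, giving an at least 3.6-fold lower number from compound 3 to compound 4 (0.56 log units; beyond the scatter). Methyl still falls short of nitro at this position, with a 7.7-fold higher number from compound 1 to compound 4 (0.89 log units; beyond the scatter), and 4-methylphenyl falls short of 3-chlorophenyl, with a 3.1-fold higher number from compound 2 to compound 4 (0.49 log units; beyond the scatter), so compound 4 sits between compound 2 and the limit of compound 3 without reaching the two compounds that gave the lowest numbers. The size of the step from fluoro to methyl stays only a bound, because the reading of compound 3 is a limit and not a number: the limit of > 100000 nM in this assay, at which 1 of the 4 values shown sits.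

The compounds shown leave open how an amine, a carboxylic acid or a methoxy group on the same carbon would read, and so whether nitro is unusual at this position or one of several groups that give a low number. As far as these compounds go, how a 4-chlorophenyl group on that nitrogen would read is also open, and with it how much of the gap to compound 2 belongs to the group itself and how much to its place on the ring.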